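Shortening a long chain on a nucleoside inhibitor

The source may hold more compounds than are shown below. What is called first, only, known or untested is meant among the compounds shown, and "the series" means these compounds.

Measured compounds:
- compound 1, `CCCCCCCCCCCCCCCCNc1nc(=O)c2ncn([C@@H]3O[C@H](CO)[C@@H](O)[C@H]3O)c2c(=O)[nH]1`: 30 ug/mL
- compound 2, `CCCCCCCCCCNc1nc(=O)c2ncn([C@@H]3O[C@H](CO)[C@@H](O)[C@H]3O)c2c(=O)[nH]1`: 500 ug/mL
- compound 3, `CCCCCCCCCCCCNc1nc(=O)c2c(ncn2[C@@H]2C[C@H](O)[C@@H](CO)O2)c(=O)[nH]1`: 150 ug/mL

In an assay on isolated protein for inhibition of ATP-dependent RNA helicase SUPV3L1, mitochondrial (Homo sapiens) (on this read-out higher numbers stand for weaker inhibition and lower numbers for stronger inhibition), compound 1 gives the lowest number of the three, the nearest being compound 3 with 150 ug/mL and the furthest compound 2 with 500 ug/mL. Compound 4, `CCCCCCCCCCCCCCNc1nc(=O)c2ncn([C@@H]3O[C@H](CO)[C@@H](O)[C@H]3O)c2c(=O)[nH]1`, has not been measured in this assay. The change from compound 1 to compound 4 is hydrogen in place of ethyl on a saturated chain carbon, ten or more bonds along the chain from a nitrogen on an aromatic ring. Among the compounds with values here, one measured step bears directly on this: the step from compound 1 to compound 2 removes hexyl at the same place on the chain, and it gives a 17-fold higher number from compound 1 to compound 2 (1.22 log units; beyond the scatter). Removing ethyl is a smaller cut of the same kind, so a move in the same direction, toward a higher number, is expected, but of smaller size. Compound 4 is therefore expected to show a step of a 2.3-fold higher number from compound 1 to compound 4 (0.37 log units; beyond the scatter) in this assay. The estimate for compound 4 is 70 ug/mL, with a range from 35 ug/mL to 150 ug/mL.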

Compound 4, half-maximal inhibitory concentration: 30 ug/mL
Compound 4: the middle estimate sits 2.3-fold (0.37 log units) above what was measured; measured number below the stated range.
By their numbers in this assay, from the lowest: compounds 1 and 4 (each within the scatter of the next); then compound 3; then compound 2.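

Taking ethyl off the chain gives no change at the digits printed from compound 1 to compound 4 (within the scatter) in this assay and so, at this place on the chain, makes no difference that can be seen. The large effect of chain length lies further in: butyl in place of hydrogen gives a 17-fold lower number from compound 2 to compound 4 (1.22 log units; beyond the scatter) and accounts for the whole gap once seen between the two ends of this series, so among these compounds the number does not climb evenly as the chain shortens. Nothing available explains this sharp behaviour. Where along the butyl stretch the change sets in remains open, as does whether a longer chain than that of compound 1 would lower the number further. Also open, from the compounds shown here alone, is whether a chain ending in an amine or a carboxylic acid would be tolerated at this place.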